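Bromo for methoxy on the triazole aryl group

This account rests on a few compounds, and the source may have more. Where it says the series, first, only, none or still open, it means among the compounds named here.

Compound 1, `Cc1ccc(S(=O)(=O)Oc2ccc3c(c2C)[C@H](Cn2cc(-c4ccc(Cl)cc4)nn2)[C@@]24CC(=O)[C@@](C)(CC[C@@H]32)C4)cc1`: in a functional assay on SMMC-7721 cells (Homo sapiens) for cytotoxicity, read by MTT assay, with a stated time of 4 days (a lower number here means a stronger inhibitor, a higher number a weaker inhibitor), compound 1 gives > 20000 nM, which is a limit of the assay and not a number.
Compound 2, `Cc1ccc(S(=O)(=O)Oc2ccc3c(c2C)[C@H](Cn2cc(-c4ccccn4)nn2)[C@@]24CC(=O)[C@@](C)(CC[C@@H]32)C4)cc1`: in this assay compound 2 gives > 20000 nM, again only a limit.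
Compound 3, `COc1ccc(-c2cn(C[C@H]3c4c(ccc(OS(=O)(=O)c5ccc(C)cc5)c4C)[C@@H]4CC[C@@]5(C)C[C@]43CC5=O)nn2)cc1`: in this assay compound 3 gives > 20000 nM, also only a limit.

Compound 3 therefore stands where every measured compound stands, at the limit of this assay; all three values shown sit there (the limit of > 20000 nM in this assay, at which 3 of the 3 values shown sit). The three steps among these compounds, a step that the two limits leave unreadable from compound 1 to compound 2, a step that the two limits leave unreadable from compound 1 to compound 3 and a step that the two limits leave unreadable from compound 2 to compound 3, cannot be read, since both ends of each are limits.

Compound 4, `Cc1ccc(S(=O)(=O)Oc2ccc3c(c2C)[C@H](Cn2cc(-c4ccc(Br)cc4)nn2)[C@@]24CC(=O)[C@@](C)(CC[C@@H]32)C4)cc1`, differs from compound 3 in one place: bromo in place of methoxy on an aromatic carbon. The step from compound 1 to compound 3 exchanged a halogen for methoxy on the same aromatic carbon, and it gave no readable change; the present change runs the other way, from methoxy to a halogen. Going by the values given here, with every measured value at the limit, no step of any size or direction can be derived for this assay.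

Compound 4 is therefore expected to sit at the limit as well, with an estimated value of 30000 nM, between 10000 nM and 100000 nM. This estimate means an expected step that the limit leaves unreadable from compound 3 to compound 4, nothing beyond the scatter.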

Compound 4, half-maximal inhibitory concentration: > 20000 nM
Compound 4: only a limit was reported; the forecaster's own chance of this, stated with the estimate: 85%; the middle value does not contradict the limit.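

Compound 4 gives > 20000 nM in this assay, which is a limit and not a number. No step from compound 1, compound 2 or compound 3 to compound 4 can be read, as all four compounds share one limit: the limit of > 20000 nM in this assay, at which 4 of the 4 values shown sit.

The compounds shown leave open whether any of these exchanged groups makes a compound stronger or weaker in this assay.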